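The compounds below may be only part of what the source reports. "The series", "measured", "known", "first", "only" and "open" are said of these compounds alone.

In a functional assay on HL-60 cells (Homo sapiens) for antiproliferative activity, with a stated time of 72 h (a higher number here means a weaker inhibitor, a lower number a stronger inhibitor), compound 1 `OC[C@H]1O[C@@H](n2cnc3c(NCc4cccc(F)c4)ncnc32)[C@H](O)[C@@H]1O` gives 920 nM, compound 2 `OC[C@H]1O[C@@H](n2cnc3c(NCc4ccccc4Cl)ncnc32)[C@H](O)[C@@H]1O` gives 1600 nM and compound 3 `OC[C@H]1O[C@@H](n2cnc3c(NCc4ccc(Cl)cc4)ncnc32)[C@H](O)[C@@H]1O` gives 1700 nM. These three share one core and differ only in the substituted phenyl group. Compound 3 stands level with the other two, as its value lies within the scatter of both.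

Compound 4 `OC[C@H]1O[C@@H](n2cnc3c(NCc4cccc(Br)c4)ncnc32)[C@H](O)[C@@H]1O` carries 3-bromophenyl in place of 4-chlorophenyl, on a saturated chain carbon bound to a nitrogen on an aromatic ring (3-bromophenyl in place of 4-chlorophenyl on a saturated chain carbon bound to a nitrogen on an aromatic ring).

The measured swaps of one phenyl group for another are the best guide to this change. They are a 1.7-fold higher number from compound 1 to compound 2 (0.24 log units; within the scatter), a 1.8-fold higher number from compound 1 to compound 3 (0.27 log units; within the scatter) and a 1.1-fold higher number from compound 2 to compound 3 (0.03 log units; within the scatter). None of them goes beyond the scatter, so no step beyond the scatter is expected in this assay. Of the measured groups, the 3-fluorophenyl of compound 1, at 920 nM, reads closest by name to 3-bromophenyl, so the estimate leans slightly towards it. The expected change is a 1.4-fold lower number from compound 3 to compound 4 (0.15 log units; within the scatter), which is an estimate. For compound 4 the expected value is about 1200 nM, with an estimated range of 550 nM to 2600 nM.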

Compound 4, half-maximal inhibitory concentration: 8000 nM
Beside the measured number, compound 4's estimate is 6.7-fold (0.82 log units) below it; the whole stated range lies below it.
By their numbers in this assay, from the lowest: compounds 1, 2 and 3 (each within the scatter of the next); then compound 4.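

In this assay, the phenyl group on this saturated chain carbon proves less forgiving than the first three compounds suggested: 3-bromophenyl brings a 4.7-fold higher number from compound 3 to compound 4 (0.67 log units; beyond the scatter) and a 5.0-fold higher number from compound 2 to compound 4 (0.70 log units; beyond the scatter), leaving compound 4 the weakest of the four. The most telling pair differs only by bromo in place of fluoro on an aromatic carbon, and this single swap gives an 8.7-fold higher number from compound 1 to compound 4 (0.94 log units; beyond the scatter), so for this pair the identity of the halogen matters. Nothing measured here explains why activity falls with this change.

Open, as far as these compounds go, is whether 3-chlorophenyl would read like compound 1 or like compound 4, and whether 4-bromophenyl would keep the level of compound 3. A phenyl group carrying an amine or a methoxy group instead of a halogen would show whether this position tolerates anything other than halogens.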